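A few compounds are considered here, and "the series" means these few. Any claim that something is new, unique, unknown or untested is made for them only; others in the source may bear on it.

Working notes on the aryl group on the ring nitrogen. In a functional assay on CHO cells with adenosine receptor A1 (Homo sapiens) as the target, read by cAMP accumulation and immunoassay, with a stated time of 6 min, tested at 1 uM (a higher number here means a weaker effect of the compound at the concentration tested, a lower number a stronger effect), compound 1 `Nc1scc(CN2CCN(c3ccc(Cl)cc3F)CC2)c1C(=O)c1ccc(Cl)cc1` gives -57%, compound 2 `Nc1scc(CN2CCN(c3cccc(C(F)(F)F)c3)CC2)c1C(=O)c1ccc(Cl)cc1` gives -72% and compound 3 `Nc1scc(CN2CCN(c3cc(F)cc(F)c3)CC2)c1C(=O)c1ccc(Cl)cc1` gives -66%. Among the compounds with values here, compound 2 holds the lowest of the three numbers, but this rests on a number 15 percentage points lower from compound 1 to compound 2 (beyond the scatter) alone, the only step beyond the scatter; the gap to compound 3, a number 6 percentage points higher from compound 2 to compound 3 (within the scatter), does not separate the two. The third step, a number 9 percentage points lower from compound 1 to compound 3 (within the scatter), is likewise within the scatter.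

Compound 4 `Nc1scc(CN2CCN(c3c(F)cc(F)cc3F)CC2)c1C(=O)c1ccc(Cl)cc1` has not been measured. It differs from compound 2 by 2,4,6-trifluorophenyl in place of 3-(trifluoromethyl)phenyl on an amine nitrogen in a ring. Within the data shown here, the steps that bear on this are the three aryl swaps at the same place: one modest step from compound 1 to compound 2, two steps that stay within the scatter. A move from one fluorinated phenyl to another, compound 1 to compound 3, gave a number 9 percentage points lower from compound 1 to compound 3 (within the scatter), and the swap out of the trifluoromethylphenyl, compound 2 to compound 3, gave a number 6 percentage points higher from compound 2 to compound 3 (within the scatter). From these, a step of a number 9 percentage points higher from compound 2 to compound 4 (within the scatter) is expected for compound 4, small and probably within the scatter, leaning toward a higher number. Compound 4 is therefore estimated at -63%, with a range of -78% to -46%.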

Compound 4, a percentage reported as activity, at one concentration (the size of the read-out at that concentration, not a potency): -56%
For compound 4 the middle estimate is 7 percentage points below the measured one; the range from low to high includes it.
By their numbers in this assay, from the lowest: compounds 2, 3, 1 and 4 (each within the scatter of the next, the first and the last beyond it).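

In this assay, a number 16 percentage points higher from compound 2 to compound 4 (beyond the scatter) is a second step beyond the scatter at this position, so the 3-(trifluoromethyl)phenyl group now stands apart from two of the other aryl groups rather than one. The remaining new steps, a number 10 percentage points higher from compound 3 to compound 4 (within the scatter) and a number 1 percentage points higher from compound 1 to compound 4 (within the scatter), do not separate the 2,4,6-trifluorophenyl group from the 3,5-difluorophenyl or the 4-chloro-2-fluorophenyl group. The 3,5-difluorophenyl group goes against any clean split of the set, since a number 6 percentage points higher from compound 2 to compound 3 (within the scatter) leaves it unseparated from the 3-(trifluoromethyl)phenyl group as well, and the size of the effect at this position therefore stays modest across all four aryl groups.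

Nothing on hand accounts for these steps. On these data alone, it remains open whether a phenyl ring carrying a methoxy group, a nitrile or an amine, or a saturated cyclohexyl ring in place of the aryl group, would read with compound 2 or with compound 4 in this assay.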